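Series notes: chloro for hydrogen on the outer methyl

The source may hold more compounds than are shown below. What is called first, only, known or untested is meant among the compounds shown, and "the series" means these compounds.

Measured in an assay for inhibition of 15-hydroxyprostaglandin dehydrogenase [NAD(+)] (Homo sapiens), read by fluorescence and spectrophotometry; a higher number here means a weaker inhibitor, a lower number a stronger inhibitor:
- compound 1 `O=C1N=C(O)S/C1=C\c1ccc(OCCc2ccccn2)cc1`: 660 nM
- compound 2 `Cc1ccc(COc2ccc(/C=C3\SC(O)=NC3=O)cc2)cc1`: 232 nM

Compound 2 holds the lower of the two numbers in this assay; its nearest neighbour is compound 1, and the gap is a 2.8-fold lower number from compound 1 to compound 2 (0.45 log units; beyond the scatter), a change of the whole group on the saturated chain carbon bound to the oxygen on the aromatic ring.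

Compound 3 `O=C1N=C(O)S/C1=C\c1ccc(OCc2ccc(CCl)cc2)cc1` is not yet measured. It differs from compound 2 by chloro in place of hydrogen on a saturated chain carbon bound to an aromatic carbon. Within the data shown here, no measured step touches this site: the only step in hand, a 2.8-fold lower number from compound 1 to compound 2 (0.45 log units; beyond the scatter), exchanges the entire terminal group rather than adding one atom to its methyl. That step therefore says little about the present change, and nothing in the data points in either direction for it.

On that basis the number for compound 3 in this assay is expected to stay close to that of compound 2, with an estimated step of a 1.1-fold higher number from compound 2 to compound 3 (0.03 log units; within the scatter), not beyond the scatter. The estimate for compound 3 is 250 nM, with a range from 100 nM to 650 nM.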

Compound 3, half-maximal inhibitory concentration: 124 nM
Compound 3: middle estimate off by 2.0-fold (0.30 log units), on the high side, within the range that was stated.
By their numbers in this assay, from the lowest: compounds 3 and 2 (each within the scatter of the next); then compound 1.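

In this assay, chloro in place of hydrogen on this saturated chain carbon bound to an aromatic carbon gives a 1.9-fold lower number from compound 2 to compound 3 (0.27 log units; within the scatter) and so stays within the scatter: the change from methyl to chloromethyl is accepted here, and this assay does not separate compound 2 from compound 3. The exchange of the whole terminal group now reads a 5.3-fold lower number from compound 1 to compound 3 (0.73 log units; beyond the scatter) and lies beyond the scatter, so the separation from compound 1 seen earlier with 4-methylphenyl also holds with 4-(chloromethyl)phenyl in its place. No supporting data bear on why this position accepts the added chlorine, so the result stands as an observation only.

The two compounds at this site do not show whether the chlorine itself matters or whether other groups on the same carbon would read alike, and a hydroxymethyl, an aminomethyl or a carboxylic acid there would test how far the site accepts change. On these data alone, it also remains open whether a longer chain carrying the chloro would keep the number of compound 3, which is 124 nM in this assay and would be the reference for that comparison.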